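Amide substituent changes on the shared core

A few compounds are considered here, and "the series" means these few. Any claim that something is new, unique, unknown or untested is made for them only; others in the source may bear on it.

Compound 3 `Cc1ccccc1C(=O)Nc1c(C(O)(C(F)(F)F)C(F)(F)F)ccc2ccccc12` gives 5550 nM in an assay on LtK cells with ATP-sensitive inward rectifier potassium channel 11 (Homo sapiens) as the target (a lower number here means that less compound is needed, a higher number that more compound is needed for the effect), and stands highest of the three measured numbers. Compound 1 `CC(C)CCC(=O)Nc1c(C(O)(C(F)(F)F)C(F)(F)F)ccc2ccccc12` gives 49 nM, and compound 2 `O=C(Nc1c(C(O)(C(F)(F)F)C(F)(F)F)ccc2ccccc12)C1CCCC1` gives 495 nM in this assay. The measured steps are a 110-fold higher number from compound 1 to compound 3 (2.05 log units; beyond the scatter), an 11-fold higher number from compound 2 to compound 3 (1.05 log units; beyond the scatter) and a 10-fold higher number from compound 1 to compound 2 (1.00 log units; beyond the scatter). Compound 4 `O=C(Nc1c(C(O)(C(F)(F)F)C(F)(F)F)ccc2ccccc12)c1ccc(OC(F)(F)F)cc1` differs from compound 3 as follows: 4-(trifluoromethoxy)phenyl in place of 2-methylphenyl on a carbonyl carbon. Within the data shown here, no measured step exchanges one aryl group on the carbonyl carbon for another; the steps into compound 3 show only that each aryl replacement of an alkyl group went to a higher number. Compound 4 is therefore expected to remain near the same level, the estimated step being a 1.4-fold lower number from compound 3 to compound 4 (0.14 log units; within the scatter), with wide uncertainty. The estimate for compound 4 is 4000 nM, with a range from 1000 nM to 16000 nM.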

Compound 4, half-maximal effective concentration: > 10000 nM
Compound 4 gave a limit, no number; the forecaster's own chance of this, stated with the estimate: 10%; middle value at least 2.5-fold (0.39 log units) away from the limit.
By their numbers in this assay, from the lowest: compound 1; then compound 2; then compound 3. At a limit, above all of these: compound 4.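

Compound 4 gives only a limit of the assay, not a number: the limit of > 10000 nM in this assay, at which 1 of the 4 values shown sits. This first exchange of one aryl group for another on the carbonyl carbon does not separate the two aryl amides (an at least 1.8-fold higher number from compound 3 to compound 4 (0.25 log units; that floor lies within the scatter)). The rise from alkyl to aryl now holds for a second aryl group (an at least 20-fold higher number from compound 2 to compound 4 (1.30 log units; beyond the scatter); an at least 200-fold higher number from compound 1 to compound 4 (2.30 log units; beyond the scatter)), and no compound shown goes against it.

Going by these compounds, how far the number for compound 4 lies above that for compound 3 stays open. Also open, on these data alone, is whether a longer chain than isopentyl, or a chain ending in an amine, would give a number lower than that of compound 1.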